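The compounds below may be only part of what the source reports. "The series", "measured", "known", "first", "only" and "open" are said of these compounds alone.

In an ADME assay on microsomes from liver (Mus musculus, strain CD1) for metabolic stability, read by LC-MS, with a stated time of 30 min, tested at 10 uM (a lower number here means that less of the compound is left, a higher number that more of the compound is left), compound 1 (`COc1ccc(-c2nc3c(N4CCN(Cc5cc(C)on5)CC4)c(Br)cnc3[nH]2)cc1`) gives > 50% as a limit, not a number. Compound 2 (`Cc1cc(CN2CCN(c3c(Cl)cnc4[nH]c(-c5ccc(CN)cc5)nc34)CC2)no1`) gives > 50% which is also a limit. Compound 3 (`Cc1cc(CN2CCN(c3c(Cl)cnc4[nH]c(N5CCN(C)CC5)nc34)CC2)no1`) gives > 50% and this too is only a limit. Among the measured compounds shown here, the whole picture so far is the limit of > 50% in this assay, at which 3 of the 3 values shown sit, and so no compound can be ranked against another.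

Compound 4 (`Cc1cc(CN2CCN(c3c(Br)cnc4[nH]c(-c5ccc(OCCO)cc5)nc34)CC2)no1`) is built from compound 1 by one change. It carries hydroxymethyl in place of hydrogen on a saturated chain carbon bound to an oxygen on an aromatic ring and so turns methoxy into 2-hydroxyethoxy, or 4-methoxyphenyl into 4-(2-hydroxyethoxy)phenyl.

For the measured compounds named here, only one measured step exists, a step that the two limits leave unreadable from compound 2 to compound 3 as the change. It has no readable size, and it concerns a different group from the one altered here. It therefore offers no guide to the size or direction of the new step. With nothing measured against it, no step beyond the usual scatter is expected, and no direction can be favoured. The expected step is a step that the limit leaves unreadable from compound 1 to compound 4 in this estimate. Compound 4 is expected to read about 62% in this assay with an estimated range of 40% to 88% and a real chance of another bare limit.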

Compound 4, percent of the compound remaining in the Mus musculus assay: > 50%
Compound 4 gave a limit, no number; the forecaster's own chance of this, stated with the estimate: 55%; the middle value does not contradict the limit.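

In the Mus musculus assay, compound 1 gives > 50%, which is a limit, not a number. In the Mus musculus assay, compound 4 gives > 50%, which is also only a limit. So no step between them can be read: the limit of > 50% in the Mus musculus assay, at which 4 of the 4 values shown sit.

In a physicochemical assay for solubility (a lower number here means a less soluble compound, a higher number a more soluble compound), compound 1 gives < 10 ug/mL, which is a limit, not a number. In the physicochemical assay, compound 4 gives 10 ug/mL.

The compounds shown leave open how much of each one actually remains in the Mus musculus assay, and whether hydroxymethyl in place of hydrogen makes any difference to that amount.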